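Methoxy in place of carboxymethylamino: cytotoxicity on Huh-7 cells

The source may report more compounds than this note shows. Statements on the series, on what has been measured and on what is new or still open speak of the compounds shown alone.

Compound 1 `CN(Cc1ncnc2c1ncn2[C@@H]1O[C@H](CO)[C@@H](O)[C@H]1O)c1ccccc1` gives 21000 nM in a functional assay on Huh-7 cells (Homo sapiens) for cytotoxicity, read by MTT assay, with a stated time of 3 days; on this read-out lower numbers stand for higher toxicity in this test and higher numbers for lower toxicity in this test.
Compound 2 `OC[C@H]1O[C@@H](n2cnc3c(Cn4ccc5ccccc54)ncnc32)[C@H](O)[C@@H]1O` reaches only the limit > 250000 nM in this assay.
Compound 3 `O=C(O)CNCc1ncnc2c1ncn2[C@@H]1O[C@H](CO)[C@@H](O)[C@H]1O` reaches only the limit > 100000 nM in this assay.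

Compound 3 therefore stands at a limit of this assay, not at a number; compound 2 likewise sits at a limit, and only compound 1 gives a value. The step of an at least 4.7-fold higher number from compound 1 to compound 3 (0.67 log units; beyond the scatter) is at least modest, while a step that the two limits leave unreadable from compound 2 to compound 3 cannot be read, and an at least 11-fold higher number from compound 1 to compound 2 (1.07 log units; beyond the scatter) is large. Compound 4 `COCc1ncnc2c1ncn2[C@@H]1O[C@H](CO)[C@@H](O)[C@H]1O` differs from compound 3 by methoxy in place of (carboxymethyl)amino on a saturated chain carbon bound to an aromatic carbon. Among the compounds with values here, no measured step covers this change directly; the group leaving is a substituent that gave a limit, so no readable step is expected in this assay. Compound 4 is estimated at 90000 nM, within 20000 nM to 300000 nM, meaning an expected step of an at least 1.1-fold lower number from compound 3 to compound 4 (0.04 log units; that floor lies within the scatter).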

Compound 4, half-maximal cytotoxic concentration: > 100000 nM
Compound 4 gave a limit, no number; the forecaster's own chance of this, stated with the estimate: 60%; at least 1.1-fold (0.04 log units) between middle value and limit.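

Compound 4 ends at a limit and not at a number, the same limit as compound 3: the limit of > 100000 nM in this assay, at which 2 of the 4 values shown sit. In this assay, methoxy in place of methyl(phenyl)amino gives an at least 4.7-fold higher number from compound 1 to compound 4 (0.67 log units; beyond the scatter), so a group with no hydrogen-bond donors also reaches a limit at this place, as (carboxymethyl)amino does. The steps among compounds 2, 3 and 4 cannot be read, and of the four groups shown, only methyl(phenyl)amino gives a number.

Going by these compounds, how far the three limited compounds lie past their limits stays open. On these data alone, it is also open whether phenoxy or a plain phenylamino on this carbon would give a number.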